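A Methoxy Added to the Benzyl Ring of Compound 2

This account rests on a few compounds, and the source may have more. Where it says the series, first, only, none or still open, it means among the compounds named here.

Compound 1 `Cc1ccc(OCc2ccccc2)c(C/C=C/c2ccccc2/C=C/C(=O)NS(=O)(=O)c2cccs2)c1`: 10 nM
Compound 2 `O=C(/C=C/c1ccccc1/C=C/Cc1ccccc1)NS(=O)(=O)c1cccs1`: 5 nM

In an assay on isolated protein for binding affinity to prostaglandin E2 receptor EP3 subtype (Homo sapiens) (a lower number here means a stronger inhibitor, a higher number a weaker inhibitor), compound 1 gives 10 nM, and compound 2 gives 5 nM. Within the data shown here, compound 2 holds the lower of the two numbers, with compound 1 as its only neighbour and the gap between them within the scatter. Compound 3 `COc1ccc(C/C=C/c2ccccc2/C=C/C(=O)NS(=O)(=O)c2cccs2)cc1` differs from compound 2 by methoxy in place of hydrogen on an aromatic carbon. Among the measured compounds shown here, no step between measured compounds is known here. Since compound 1, which bears substituents on that ring, gives 10 nM, the step in this assay is expected to be none beyond the scatter, no change at the digits printed from compound 2 to compound 3 (within the scatter). Compound 3 is estimated at 5 nM, between 2 nM and 15 nM.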

Compound 3, inhibition constant: 2.4 nM
Estimate against measurement, compound 3: 2.1-fold (0.32 log units) above; the measured number falls inside the stated range.
By their numbers in this assay, from the lowest: compound 3; then compounds 2 and 1 (each within the scatter of the next).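

In this assay, among these compounds, the change from benzyl to 4-methoxybenzyl gives a 2.1-fold lower number from compound 2 to compound 3 (0.32 log units; beyond the scatter) and is the first step here between compounds that differ in one place. It shows that this carbon, para to a large group, accepts a methoxy with a modest gain beyond the scatter rather than a loss. No measurement shown here accounts for that gain. The compounds shown leave open whether a hydroxyl, an amine or a carboxylic acid at this carbon would move the number the same way, and whether the methoxy would do so elsewhere on the ring.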